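A few compounds are considered here, and "the series" means these few. Any claim that something is new, unique, unknown or untested is made for them only; others in the source may bear on it.

Compound 3 `COCCNC(=C\C(=O)/C=C/c1ccc(O)cc1)/C=C/c1ccc(O)cc1` gives 82.5% in an ADME assay on CHO-K1 cells (Cricetulus griseus) for activation, read by fluorescence, tested at 1 uM (on this read-out higher numbers stand for a weaker effect at the one concentration tested and lower numbers for a stronger effect), the lowest of the three numbers recorded so far. Compound 2 `O=C(/C=C(/C=C/c1ccc(O)cc1)NCCCO)/C=C/c1ccc(O)cc1` gives 86.4%, which lies within the scatter of compound 3, while compound 1 `COCCCN1C(/C=C/c2ccc(O)cc2)=CC(=O)CC1c1ccc(O)cc1` gives 97.8%, beyond the scatter and higher. Compound 4 `O=C(/C=C(/C=C/c1ccc(O)cc1)NCCO)/C=C/c1ccc(O)cc1` differs from compound 3 by hydrogen in place of methyl on an oxygen on a saturated carbon. Going by the values given here, the one measured step that bears on this change is a number 3.9 percentage points lower from compound 2 to compound 3 (within the scatter); it put a methoxy in place of a hydroxymethyl two bonds along the chain from an amine nitrogen and stayed within the scatter. The present change runs the other way, methoxy to hydroxy, so compound 4 is expected to shift by a number 2.5 percentage points higher from compound 3 to compound 4 (within the scatter), nothing beyond the scatter. Compound 4 is estimated at 85%, between 72% and 96%.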

Compound 4, a percentage reported as activity, at one concentration (the size of the read-out at that concentration, not a potency): 93.4%
Compound 4: middle estimate off by 8.4 percentage points, on the low side; low and high end bracket the measured number.
By their numbers in this assay, from the lowest: compounds 3, 2, 4 and 1 (each within the scatter of the next, the first and the last beyond it).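

In this assay, going by these compounds alone, hydrogen in place of methyl on the oxygen of the 2-methoxyethyl group gives a number 10.9 percentage points higher from compound 3 to compound 4 (beyond the scatter) and is the first step on this chain to pass the scatter. Hydroxy in place of hydroxymethyl gives a number 7 percentage points higher from compound 2 to compound 4 (within the scatter) and so leaves the two hydroxy-ended chains unresolved in this assay. The compounds shown leave open how an amine, a carboxylic acid or a longer ether chain in this place would read. Nothing measured here accounts for the step from methoxy to hydroxy.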